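Side-chain variation on a shared core: tail flick notes

The source may hold more compounds than are shown below. What is called first, only, known or untested is meant among the compounds shown, and "the series" means these compounds.

Measured compounds:
compound 1, `N=C(N)NCCC[C@H](NC(=O)CN(c1nc(Cl)nc2[nH]cnc12)C1CC1)C(=O)OCc1ccccc1`, gives 10.2% in a functional assay on the whole organism (Tail, strain ICR) with Mus musculus as the target, in the tail flick test, with a stated time of 120 min, at a dose of 25 umol/kg by the oral route; a lower number here means a weaker effect, a higher number a stronger effect of the compound at the dose given
compound 2, `NC(=O)CC[C@H](NC(=O)CN(c1ncnc2c1ncn2C1CCCCO1)C1CC1)C(=O)OCc1ccccc1`, gives 22.3% in this assay
compound 3, `O=C(CN(c1nc(Cl)nc2[nH]cnc12)C1CC1)NCC(=O)OCc1ccccc1`, gives 21.7% in this assay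

Compound 2 carries the highest of the three numbers, but compound 3 sits within the scatter of it; only compound 1 lies beyond the scatter below. For the measured compounds named here, the single step between neighbours, a number 11.5 percentage points higher from compound 1 to compound 3 (beyond the scatter), concerns a different side-chain change on a different core. Compound 4, `CC(C)C[C@H](NC(=O)CN(c1ncnc2c1ncn2C1CCCCO1)C1CC1)C(=O)OCc1ccccc1`, differs from compound 2 by isopropyl in place of carbamoylmethyl on a saturated chain carbon, two bonds along the chain from an amide-type nitrogen and a carbonyl carbon. Going by the values given here, no measured step bears on this exchange, so in this assay no step beyond the scatter is expected; the expected step is a number 2.3 percentage points lower from compound 2 to compound 4 (within the scatter). Compound 4 is therefore estimated at 20%, with a range from 8% to 32%.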

Compound 4, a percentage reported as activity, at one dose (the size of the read-out at that dose, not a potency): 12.8%
Compound 4: the middle estimate sits 7.2 percentage points above what was measured; low and high end bracket the measured number.
By their numbers in this assay, from the lowest: compounds 1, 4, 3 and 2 (each within the scatter of the next, the first and the last beyond it).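

In this assay, for the compounds shown here, the first exchange at this chain carbon on the shared core gives a number 9.5 percentage points lower from compound 2 to compound 4 (within the scatter) and so stays inside the scatter, even though the hydrogen-bond donor and acceptor counted on carbamoylmethyl leave with it. No measurement on hand explains the step or ties it to any property of either group.

From the compounds shown here alone, whether an amine, a carboxylic acid or a longer chain at this carbon would give a step beyond the scatter stays open. So does whether isopropyl in place of carbamoylmethyl reads the same on the core of compound 1.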